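Moving the Pyridine Nitrogen in a Urea

A few compounds are considered here, and "the series" means these few. Any claim that something is new, unique, unknown or untested is made for them only; others in the source may bear on it.

compound 1 `N#Cc1ccc(NC(=O)Nc2ccnc(C(F)(F)F)c2)cc1` at 3
compound 2 `O=C(Nc1ccc(F)c(C(F)(F)F)c1)Nc1ccccn1` at 3.7
compound 3 `NC(=O)c1ccccc1NC(=O)Nc1ccc(F)c(C(F)(F)F)c1` at 3.3

All three compounds were read in a physicochemical assay for lipophilicity, read by HPLC, measured as octanol-water partition, at pH 7.2; a higher number here means a more lipophilic compound, a lower number a more polar compound. Compound 2 stands highest at 3.7. Its nearest neighbour is compound 3 at 3.3, and furthest away lies compound 1 at 3, with both gaps beyond the usual scatter of repeated measurements.

Compound 4 `O=C(Nc1ccncc1)Nc1ccc(F)c(C(F)(F)F)c1` has not yet been measured. It has the same atoms as compound 2, joined differently: pyridin-4-yl in place of pyridin-2-yl on an amide-type nitrogen. In words, pyridin-4-yl stands in place of pyridin-2-yl on an amide-type nitrogen.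

Among the measured compounds shown here, no measured pair shows this change, so the three values give no direct size for it, and the expectation is a matter of judgement. With compound 2 at the top of the three, the expected direction is downward, by a step beyond the scatter, although a smaller move cannot be ruled out. In this assay the estimated change is a number 0.70 log units lower from compound 2 to compound 4 (beyond the scatter). Compound 4 is expected at 3, within an estimated range of 2.5 to 3.5.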

Compound 4, distribution coefficient: 3.2
Compound 4: middle estimate off by 0.20 log units, on the low side; measured number inside the range.
By their numbers in this assay, from the lowest: compounds 1, 4 and 3 (each within the scatter of the next); then compound 2.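

Among the compounds shown here, compound 2 and compound 4 form the first pair in this set that differs in one place, and in this assay pyridin-4-yl in place of pyridin-2-yl on an amide-type nitrogen gives a number 0.50 log units lower from compound 2 to compound 4 (beyond the scatter). The earlier compounds shown here could give no size for this change, whereas this pair has the same atoms, joined differently, and the step lies beyond the scatter. At this position, then, moving the pyridine nitrogen alone, with the rest of the molecule unchanged, is enough to shift the number by a modest but readable amount, and nothing measured here explains the step.

The compounds shown leave open where pyridin-3-yl on the same amide-type nitrogen would stand relative to compound 2 and compound 4. For the compounds shown here, they also leave open whether a step of this size would recur with a methyl group or an amine added to the pyridine ring, or with a different group on the other side of the urea, as this single pair gives only one instance of the change.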